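One Hydroxyl in Place of Two Methyls

This account rests on a few compounds, and the source may have more. Where it says the series, first, only, none or still open, it means among the compounds named here.

Compound 3 `Cc1ccc(C)c(/C=C(/SCc2ccc(Cl)cc2)C(=O)c2ccc(Cl)cc2)c1` was tested in a functional assay on DU-145 cells (Homo sapiens) for inhibition, read by trypan blue exclusion, with a stated time of 96 h (a lower number here means a stronger inhibitor of growth, a higher number a weaker inhibitor of growth), and compound 3 gives 10000 nM. Compound 1 `COc1ccc(/C=C(/SCc2ccc(Cl)cc2)C(=O)c2ccc(Cl)cc2)cc1` gives 10000 nM in this assay, and the step of no change at the digits printed from compound 1 to compound 3 (within the scatter) shows that compound 3 stands level with compound 1. Compound 2 `O=C(/C(=C\c1c(O)cc(O)cc1O)SCc1ccc(Cl)cc1)c1ccc(Cl)cc1` reaches only a limit of this assay, > 100000 nM. The step of an at least 10-fold higher number from compound 1 to compound 2 (1.00 log units; beyond the scatter) is therefore a clear weakening, as the limit of > 100000 nM in this assay, at which 1 of the 3 values shown sits, records. Compound 4 `O=C(/C(=C\c1ccc(O)cc1)SCc1ccc(Cl)cc1)c1ccc(Cl)cc1` has not yet been measured. Its change from compound 3 is 4-hydroxyphenyl in place of 2,5-dimethylphenyl on a double-bonded chain carbon bound to a double-bonded chain carbon. This carries one hydroxyl, a smaller move toward compound 2 than the three hydroxyls of that compound, while the swap of methyls for a methoxy between compound 3 and compound 1 left the number unchanged. A mild weakening is therefore expected for compound 4, a 2.5-fold higher number from compound 3 to compound 4 (0.40 log units; beyond the scatter), with a real chance that only a limit is returned. Compound 4 is estimated at 25000 nM, within a range from 6000 nM to 100000 nM.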

Compound 4, concentration for 50% growth inhibition: 10000 nM
Estimate against measurement, compound 4: 2.5-fold (0.40 log units) above; the range from low to high includes it.
By their numbers in this assay, from the lowest: compounds 1, 3 and 4 (each within the scatter of the next). At a limit, above all of these: compound 2.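

In this assay, a lone hydroxyl on the aromatic ring does not weaken growth inhibition: 4-hydroxyphenyl in place of 2,5-dimethylphenyl gives no change at the digits printed from compound 3 to compound 4 (within the scatter), and hydrogen in place of methyl on the oxygen gives no change at the digits printed from compound 1 to compound 4 (within the scatter). The presence of a hydroxyl as such therefore does not set compound 2 apart, for 4-hydroxyphenyl in place of 2,4,6-trihydroxyphenyl gives an at least 10-fold lower number from compound 2 to compound 4 (1.00 log units; beyond the scatter). Compound 2 gives > 100000 nM, which is a limit and not a number.

The compounds shown leave open whether the loss in compound 2 needs all three hydroxyls or only some of them, as none here carries two. They also leave open what an amine or a carboxylic acid on the aromatic ring would do to the number.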